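From chloromethyl to diisopropylamino on the shared core

This account rests on a few compounds, and the source may have more. Where it says the series, first, only, none or still open, it means among the compounds named here.

In a functional assay on MCF7 cells (Homo sapiens) for antiproliferative activity, read by MTT assay, with a stated time of 48 h (on this read-out lower numbers stand for stronger inhibition and higher numbers for weaker inhibition), compound 1 (`CC(C)=CCC[C@]1(C)/C=C/[C@@H](OC(=O)C=C(C)C)[C@](C)(O)/C=C/C(=O)/C(CF)=C\C1`) gives 240 nM, while compound 2 (`CC(C)=CCC[C@]1(C)/C=C/[C@@H](OC(=O)C=C(C)C)[C@](C)(O)/C=C/C(=O)/C(CCl)=C\C1`) gives 610 nM, the higher of the two numbers. Compound 3 (`CC(C)=CCC[C@]1(C)/C=C/[C@@H](OC(=O)C=C(C)C)[C@](C)(O)/C=C/C(=O)/C(CN(C(C)C)C(C)C)=C\C1`) has diisopropylamino in place of chloro on a saturated chain carbon bound to a double-bonded ring carbon. Within the data shown here, only one measured step bears on this place, the modest 2.5-fold higher number from compound 1 to compound 2 (0.41 log units; beyond the scatter), and it exchanges chloro for fluoro. Among the measured compounds shown here, no measured compound carries an amino group there, so the expectation is loose: a modest rise in this assay. The expected change is a 1.6-fold higher number from compound 2 to compound 3 (0.21 log units; within the scatter). The estimated value for compound 3 is 1000 nM, with an expected range of 300 nM to 3500 nM.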

Compound 3, half-maximal inhibitory concentration: 780 nM
Beside the measured number, compound 3's estimate is 1.3-fold (0.11 log units) above it; the range from low to high includes it.
By their numbers in this assay, from the lowest: compound 1; then compounds 2 and 3 (each within the scatter of the next).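

In this assay, the much larger diisopropylamino group takes the place of chloro with a 1.3-fold higher number from compound 2 to compound 3 (0.11 log units; within the scatter), so at this place an amine and a halogen cannot be told apart by this read-out. Set against fluoro, the same amine gives a 3.3-fold higher number from compound 1 to compound 3 (0.51 log units; beyond the scatter), which leaves compound 1 with the lowest number of the three. No evidence at hand accounts for these numbers. As far as these compounds go, how dimethylamino, morpholine or a hydroxyl group would read at this place stays open. The compounds shown also vary this one place only, so the ester on the shared core remains untested here.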